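The compounds below may be only part of what the source reports. "The series", "measured", "known", "first", "only" and "open" are said of these compounds alone.

In a functional assay on L1210 cells (Mus musculus) for inhibition, with a stated time of 96 h (a higher number here means a weaker inhibitor, a lower number a stronger inhibitor), compound 1 (`CCNCCCCNCCCN`) gives 40000 nM and compound 2 (`CCCNCCCCNCCCN`) gives 55000 nM within the scatter of each other. Compound 3 (`CCNCCCCCNCCCCNCC`) is still unmeasured. It differs from compound 1 by 2-(ethylamino)ethyl in place of amino on a saturated chain carbon, three bonds along the chain from an amine nitrogen in one change: 2-(ethylamino)ethyl in place of amino on a saturated chain carbon, three bonds along the chain from an amine nitrogen. Among the compounds with values here, the only measured step is a 1.4-fold higher number from compound 1 to compound 2 (0.14 log units; within the scatter) for a single methyl, a much smaller change and so a weak guide. No step beyond the scatter is therefore expected in this assay and the uncertainty is wide. The expected step is a 1.6-fold lower number from compound 1 to compound 3 (0.20 log units; within the scatter) on this estimate. For compound 3 the estimated value is 25000 nM with an expected range from 3000 nM to 80000 nM in this test.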

Compound 3, half-maximal inhibitory concentration: 200 nM
Beside the measured number, compound 3's estimate is 130-fold (2.10 log units) above it; measured number below the stated range.
By their numbers in this assay, from the lowest: compound 3; then compounds 1 and 2 (each within the scatter of the next).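

In this assay, within the data shown here, the change to 2-(ethylamino)ethyl in place of amino gives a 200-fold lower number from compound 1 to compound 3 (2.30 log units; beyond the scatter) and is the first step here beyond the scatter, whereas the earlier methyl step gives a 1.4-fold higher number from compound 1 to compound 2 (0.14 log units; within the scatter) and stays within it. So a saturated chain carbon, three bonds along the chain from an amine nitrogen, can carry a larger amine-bearing group with a large gain in potency. Nothing measured here accounts for that gain. The compounds shown leave open whether the added nitrogen matters or the added carbons alone suffice, which a plain butyl group at this place would test. They also leave open how a longer chain ending in an amine would compare.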